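The source may report more compounds than this note shows. Statements on the series, on what has been measured and on what is new or still open speak of the compounds shown alone.

Measured compounds:
compound 1 `OC(Cc1ccccc1)c1cc(Br)cc2[nH]ncc12` — 140 nM
compound 2 `CCc1cc(C(O)Cc2ccccc2)c2cn[nH]c2c1` — 740 nM

In an assay for binding affinity to Indoleamine 2,3-dioxygenase 1 (Homo sapiens), read by spectrophotometry, with a stated time of 30 min (on this read-out higher numbers stand for weaker binding and lower numbers for tighter binding), compound 1 gives 140 nM, and compound 2 gives 740 nM. Going by the values given here, compound 2 therefore holds the higher of the two numbers in this assay, its nearest neighbour being compound 1, and the one step that joins them, a 5.3-fold higher number from compound 1 to compound 2 (0.72 log units; beyond the scatter), is a modest one that lies beyond the scatter.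

Compound 3 `OC(Cc1ccccc1)c1cc(-c2ccccc2)cc2[nH]ncc12` has not yet been measured in this assay. It differs from compound 2 in one place: phenyl in place of ethyl on an aromatic carbon. Among the compounds with values here, the only measured step that touches this position is a 5.3-fold higher number from compound 1 to compound 2 (0.72 log units; beyond the scatter), which exchanged one small group for another and cost a modest amount of affinity. Within the data shown here, no measured pair shows what a phenyl does at this carbon, so the direction of the next step cannot be read from the two values alone. Taking the single known step as a guide to the size of change this position tolerates, compound 3 is expected to land near compound 2, with a step of a 1.5-fold lower number from compound 2 to compound 3 (0.17 log units; within the scatter) in this assay. The estimate for compound 3 is 500 nM, within a range from 150 nM to 2000 nM.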

Compound 3, dissociation constant: 53000 nM
Compound 3: middle estimate off by 110-fold (2.03 log units), on the low side, outside the stated range (above it).
By their numbers in this assay, from the lowest: compound 1; then compound 2; then compound 3.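

In this assay the exchange of ethyl for phenyl proves a far larger move than the earlier exchange of bromo for ethyl, with a 72-fold higher number from compound 2 to compound 3 (1.86 log units; beyond the scatter) set against the earlier 5.3-fold higher number from compound 1 to compound 2 (0.72 log units; beyond the scatter) on the same aromatic carbon. Measured directly against bromo, the phenyl gives a 380-fold higher number from compound 1 to compound 3 (2.58 log units; beyond the scatter) as the widest step among these compounds, so this position does not take every group alike: compound 1 and compound 2 stay much closer to each other than either does to compound 3. Nothing at hand explains why the phenyl is tolerated so poorly.

The three compounds leave open whether the loss belongs to the phenyl ring itself or to any group larger than ethyl, a question that a cyclopropyl group, a methoxy group or a pyridine ring at this carbon would help to settle. They also do not show whether a chloro or methyl group would match the bromo, or whether an amine carried on the phenyl would recover any of the lost binding.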